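A pyridin-3-yl swap on compound 3

This account rests on a few compounds, and the source may have more. Where it says the series, first, only, none or still open, it means among the compounds named here.

Within the data shown here, in a functional assay on HCT-15 cells (Homo sapiens) for cytotoxicity, read by ELISA, with a stated time of 2 days (on this read-out higher numbers stand for weaker inhibition and lower numbers for stronger inhibition), compound 3 (`Oc1ccc(-c2cc(-c3ccccc3)cc(-c3ccccc3)n2)cc1`) gives 3700 nM and holds the lowest of the three numbers measured so far. The other two are compound 1 (`Oc1cccc(-c2cc(-c3ccccc3)cc(-c3ccccc3)n2)c1`) with 9950 nM and compound 2 (`Oc1cccc(-c2cc(-c3ccccc3)cc(-c3ccco3)n2)c1`) with 13500 nM as their readings. Compound 4 (`Oc1ccc(-c2cc(-c3ccccc3)cc(-c3cccnc3)n2)cc1`) keeps the 4-hydroxyphenyl group of compound 3 but carries pyridin-3-yl in place of phenyl on an aromatic carbon. The nearest guide is another exchange of phenyl for a ring with a hetero atom: furan-2-yl in place of phenyl gave a 1.4-fold higher number from compound 1 to compound 2 (0.13 log units; within the scatter) and so left the number inside the usual noise. The change to 4-hydroxyphenyl gave a 2.7-fold lower number from compound 1 to compound 3 (0.43 log units; beyond the scatter) but is a different exchange, and compound 4 already has that group. Among the measured compounds shown here, with only one comparable swap to go on, the expected result in this assay is no shift beyond the scatter, an estimated 1.2-fold higher number from compound 3 to compound 4 (0.09 log units; within the scatter) with no firm direction. The estimate for compound 4 is 4500 nM (range 1800 nM to 11000 nM).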

Compound 4, half-maximal inhibitory concentration: 15100 nM
The estimate for compound 4 lay 3.4-fold (0.53 log units) below the measured number; the measured number lies above the stated range.
By their numbers in this assay, from the lowest: compound 3; then compounds 1, 2 and 4 (each within the scatter of the next).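

In this assay, the ring at this position, next to the ring nitrogen, turns out to matter: pyridin-3-yl in place of phenyl gives a 4.1-fold higher number from compound 3 to compound 4 (0.61 log units; beyond the scatter), whereas furan-2-yl in place of phenyl gave only a 1.4-fold higher number from compound 1 to compound 2 (0.13 log units; within the scatter), though on a different hydroxyphenyl parent. The heavy-atom count stays the same, and the entering ring differs from phenyl by one ring nitrogen and one hydrogen-bond acceptor, so a small change in atoms is enough to take away the low number of compound 3. No supporting data accompany these numbers to explain the rise.

The compounds shown leave open whether the presence of a ring nitrogen or its place in the ring drives this step, a question that pyridin-4-yl or pyridin-2-yl at this position could address. As far as these compounds go, it is also open whether a non-aromatic group here, such as a piperidine or a simple amine, would behave like either ring.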